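Carbamate series at the M5 receptor: replacing the aryl group

This account rests on a few compounds, and the source may have more. Where it says the series, first, only, none or still open, it means among the compounds named here.

Measured so far in an assay on CHO cells for displacement of a labelled ligand from muscarinic acetylcholine receptor M5 (Homo sapiens), read by scintillation counting, with a stated time of 2 h; on this read-out higher numbers stand for weaker inhibition and lower numbers for stronger inhibition:
compound 1 `COc1ccc(COC(=O)N(c2ccccc2)C2CN3CCC2CC3)cc1` gives 470 nM
compound 2 `COc1ccc(CCCOC(=O)N(c2ccccc2)C2CN3CCC2CC3)cc1F` gives 260 nM
compound 3 `O=C(OCc1ccccc1)N(c1ccccc1)C1CN2CCC1CC2` gives 150 nM

Compound 2 stands second highest of the three numbers in this assay, with compound 3 nearest and compound 1 furthest, both gaps within the scatter, so no order among the three can be drawn from these values alone.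

Compound 4 `O=C(OCCCc1ccc(Cl)c(Cl)c1)N(c1ccccc1)C1CN2CCC1CC2` has not yet been measured. It differs from compound 2 as follows: 3,4-dichlorophenyl in place of 3-fluoro-4-methoxyphenyl on a saturated chain carbon, three bonds along the chain from an oxygen next to a carbonyl group

Going by the values given here, only one measured step touches this change. Removing the methoxy group in going from compound 1 to compound 3 gave a 3.1-fold lower number from compound 1 to compound 3 (0.50 log units; beyond the scatter). Among the compounds with values here, the step from compound 2 to compound 4 also removes a methoxy group, but in addition it removes fluorine and adds two chlorines on the ring, and no measured pair isolates either of those changes. The methoxy removal alone points to a modestly lower number in this assay; the remaining part of the change is uncharted.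

Compound 4 is therefore expected to give 150 nM in this assay, within 50 nM to 450 nM, that is an estimated 1.7-fold lower number from compound 2 to compound 4 (0.24 log units; within the scatter).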

Compound 4, inhibition constant: 130 nM
Estimate against measurement, compound 4: 1.2-fold (0.06 log units) above; the measured number falls inside the stated range.
By their numbers in this assay, from the lowest: compounds 4, 3, 2 and 1 (each within the scatter of the next, the first and the last beyond it).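

The position on the saturated chain carbon accepts a full exchange of ring substituents: in this assay 3,4-dichlorophenyl in place of 3-fluoro-4-methoxyphenyl gives a 2.0-fold lower number from compound 2 to compound 4 (0.30 log units; within the scatter) and so separates the two compounds by no more than the scatter. The ring leaving has one hydrogen-bond acceptor and the ring entering has none, yet this exchange stays within the scatter, whereas the removal of methoxy on the chain of compounds 1 and 3 gives a 3.1-fold lower number from compound 1 to compound 3 (0.50 log units; beyond the scatter) and lies beyond it, so that step does not carry over as a general rule for methoxy loss across chains. No measurement on hand accounts for either step.

Going by these compounds alone, the separate parts of the exchange remain unresolved, as no pair isolates the loss of methoxy, the loss of fluorine or the entry of either chlorine on this chain, and no pair compares the same ring on the two chains. Also open, going by these compounds, is how this position responds to a ring bearing an amine, a carboxylic acid or a nitrile, or to a longer chain.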